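The source may hold more compounds than are shown below. What is called first, only, known or untested is meant among the compounds shown, and "the series" means these compounds.

Measured in an ADME assay on SK-OV-3 cells (Homo sapiens) for cytotoxicity, read by sulforhodamine B assay, with a stated time of 48 h, tested at 10 uM; a higher number here means more inhibition at the concentration tested (going by the name of the read-out), a lower number less inhibition:
compound 1 `CCCCCCCc1cn(C(c2ccccc2)c2cc3cc(Br)ccc3nc2OC)nn1` gives 10.5%
compound 2 `COc1nc2ccc(Br)cc2cc1C(c1ccccc1)n1cc(-c2ccccc2)nn1` gives 13.7%
compound 3 `CCCCCCCCc1cn(C(c2ccccc2)c2cc3cc(Br)ccc3nc2OC)nn1` gives 2.06%

Among the measured compounds shown here, compound 2 holds the highest of the three numbers, but the step of a number 3.2 percentage points higher from compound 1 to compound 2 (within the scatter) is within the scatter, so only the step of a number 11.6 percentage points lower from compound 2 to compound 3 (beyond the scatter) separates it from another compound.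

Compound 4 `COc1nc2ccc(Br)cc2cc1C(c1ccccc1)n1cc(CCO)nn1` is not yet measured. It differs from compound 2 by 2-hydroxyethyl in place of phenyl on an aromatic carbon. For the measured compounds named here, the steps that bear on this position are a number 3.2 percentage points higher from compound 1 to compound 2 (within the scatter) and a number 11.6 percentage points lower from compound 2 to compound 3 (beyond the scatter): swapping the phenyl for a heptyl or an octyl chain moved the number little or modestly downward. Going by the values given here, no measured step puts a 2-hydroxyethyl at this carbon, so the expected step of a number 4.7 percentage points lower from compound 2 to compound 4 (within the scatter) is small, most likely none beyond the scatter. Compound 4 is estimated at 9%, within -3% to 22%.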

Compound 4, a percentage reported as inhibition, at one concentration (the size of the read-out at that concentration, not a potency): 8.46%
Beside the measured number, compound 4's estimate is 0.5 percentage points above it; low and high end bracket the measured number.
By their numbers in this assay, from the lowest: compounds 3, 4, 1 and 2 (each within the scatter of the next, the first and the last beyond it).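

In this assay the aromatic carbon of the five-membered ring takes a hydroxy-bearing chain: 2-hydroxyethyl in place of phenyl gives a number 5.2 percentage points lower from compound 2 to compound 4 (within the scatter) for this change. Against the alkyl chains the same group gives a number 2 percentage points lower from compound 1 to compound 4 (within the scatter) and a number 6.4 percentage points higher from compound 3 to compound 4 (within the scatter) as its steps, so compound 4 stays within the scatter of all three earlier compounds, although compound 2 and compound 3 lie beyond it from each other. No measurement here explains these small steps.

Still open, as far as these compounds go, is whether an amine or a carboxylic acid at this carbon would move the number beyond the scatter. A longer hydroxyalkyl chain poses the same question.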